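From compound 2 to compound 3: one aromatic group exchanged

The compounds below may be only part of what the source reports. "The series", "measured", "known", "first", "only" and "open" are said of these compounds alone.

Measured so far in an ADME assay on cells (Homo sapiens) for cytotoxicity, read by resazurin assay, with a stated time of 5 days; on this read-out lower numbers stand for higher toxicity in this test and higher numbers for lower toxicity in this test:
- compound 1 `O=S(=O)(Cc1nc(-c2ccc(Cl)nc2)c2sccc2n1)c1cccc(Cl)c1`: 70000 nM
- compound 2 `COc1ccc(-c2nc(CS(=O)(=O)c3cccc(Cl)c3)nc3ccsc23)cc1`: 69000 nM

With only these two numbers available, compound 2 stands level with compound 1, and neither can be ranked above the other. The next compound, compound 3 `O=S(=O)(Cc1nc(-c2cccs2)c2sccc2n1)c1cccc(Cl)c1`, carries thiophen-2-yl in place of 4-methoxyphenyl on an aromatic carbon. Among the measured compounds shown here, the only guide is the one measured step, which changed the group on that same aromatic carbon: a 1.0-fold lower number from compound 1 to compound 2 (0.01 log units; within the scatter). That exchange of one aromatic group for another left the number within the scatter, so no step beyond the scatter is expected in this assay. A single step is thin evidence, so the range is kept wide. The expected change is a 1.2-fold lower number from compound 2 to compound 3 (0.06 log units; within the scatter). For compound 3 the estimated value is 60000 nM, with an expected range from 28000 nM to 100000 nM.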

Compound 3, half-maximal cytotoxic concentration: > 50000 nM
Compound 3 was reported as a limit; the forecaster's own chance of this, stated with the estimate: 20%; the middle value lies beyond the limit too.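

In this assay compound 3 gives > 50000 nM, which is a limit and not a number. Among the compounds shown here, no step from compound 1 or compound 2 to compound 3 can therefore be read. The compounds shown leave open whether exchanging this aromatic group changes the number at all.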